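Amide substituent variation on the shared core, solubility notes

The source may report more compounds than this note shows. Statements on the series, on what has been measured and on what is new or still open speak of the compounds shown alone.

Compound 2 `COc1ccc2nc(C)cc(OCC(=O)Nc3cccnc3)c2c1` carries pyridin-3-yl on the amide nitrogen. For the measured compounds named here, in a physicochemical assay for solubility, in phosphate buffer, measured as kinetic solubility, with a stated time of 1 h, at pH 7.4 (a higher number here means a more soluble compound, a lower number a less soluble compound), compound 2 gives 32000 nM, the lower of the two numbers so far; compound 1 `COc1ccc2nc(C)cc(OCC(=O)Nc3ccccc3)c2c1` gives 63000 nM, and the step of a 2.0-fold lower number from compound 1 to compound 2 (0.29 log units; within the scatter) lies within the scatter. Compound 3 `COc1ccc2nc(C)cc(OCC(=O)Nc3cc(C)nc(C)n3)c2c1` is not yet measured. It differs from compound 2 by 2,6-dimethylpyrimidin-4-yl in place of pyridin-3-yl on an amide-type nitrogen. Going by the values given here, the only measured step at this position, a 2.0-fold lower number from compound 1 to compound 2 (0.29 log units; within the scatter), exchanges one six-membered aromatic ring for another on the same amide nitrogen and does not exceed the scatter. Among the compounds with values here, no measured pair shows the effect of a pyrimidinyl or of the two methyl groups, so the expectation rests on that single step alone. A step no larger than the scatter is therefore expected, a 1.1-fold lower number from compound 2 to compound 3 (0.03 log units; within the scatter), in either direction. Compound 3 is estimated at 30000 nM, with a range from 10000 nM to 90000 nM.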

Compound 3, solubility: 5000 nM
Estimate against measurement, compound 3: 6.0-fold (0.78 log units) above, outside the stated range (below it).
By their numbers in this assay, from the lowest: compound 3; then compounds 2 and 1 (each within the scatter of the next).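

In this assay, the entry of 2,6-dimethylpyrimidin-4-yl on the amide-type nitrogen gives a 6.4-fold lower number from compound 2 to compound 3 (0.81 log units; beyond the scatter), and measured against phenyl the same group gives a 13-fold lower number from compound 1 to compound 3 (1.10 log units; beyond the scatter). The substituent at this position can therefore shift the number beyond the scatter, which the exchange of phenyl for pyridin-3-yl alone did not show. No measurement is available that bears on the reason for this step.

The compounds shown leave open whether the step belongs to the second ring nitrogen, to the two methyl groups or to both, as 2,6-dimethylpyrimidin-4-yl brings them together. Also open, going by these compounds, is how a pyrimidin-4-yl without methyl groups, or an aromatic ring carrying an amine or a carboxylic acid, would read in this assay.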